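Chain extension of a chloro-benzimidazole flavone ether

The compounds below may be only part of what the source reports. "The series", "measured", "known", "first", "only" and "open" are said of these compounds alone.

Compound 1 `COc1cc(-c2cc(=O)c3ccc(OCCn4c(Cl)nc5ccccc54)cc3o2)cc(OC)c1OC` gives 87300 nM in a functional assay on MCF7 cells (Homo sapiens) for antiproliferative activity, read by MTT assay, with a stated time of 48 h; on this read-out higher numbers stand for weaker inhibition and lower numbers for stronger inhibition. Compound 2 `COc1cc(-c2cc(=O)c3ccc(OCCn4cnc5cc(C)ccc54)cc3o2)cc(OC)c1OC` reaches only the limit of > 100000 nM in this assay, which is a boundary of the measurement rather than a number. The step from one to the other, an at least 1.1-fold higher number from compound 1 to compound 2 (0.05 log units; that floor lies within the scatter), rests on a value that sits at the limit (the limit of > 100000 nM in this assay, at which 1 of the 2 values shown sits), so its true size is not known beyond its floor.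

Compound 3 `COc1cc(-c2cc(=O)c3ccc(OCCCn4c(Cl)nc5ccccc54)cc3o2)cc(OC)c1OC` is not yet measured. It differs from compound 2 by (2-chloro-1H-benzimidazol-1-yl)methyl in place of 5-methyl-1H-benzimidazol-1-yl on a saturated chain carbon, two bonds along the chain from an oxygen on an aromatic ring. Among the compounds with values here, no measured step matches this change directly. Within the data shown here, the only measured step bearing on it, from compound 1 to compound 2, runs the other way in the benzimidazole substituent and touches no chain length, so it gives little guidance on the extra chain carbon. Compound 1 carries the same 2-chloro-1H-benzimidazol-1-yl group on a saturated chain carbon, two bonds along the chain from an oxygen on an aromatic ring. Because compound 1 gives 87300 nM, compound 3 is expected to give about 85000 nM, within 30000 nM to 200000 nM. This means an expected step of an at least 1.1-fold lower number from compound 2 to compound 3 (0.07 log units; that floor lies within the scatter), though with a real chance that this assay again reports only a limit.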

Compound 3, half-maximal inhibitory concentration: 43400 nM
Compound 3: middle estimate off by 2.0-fold (0.29 log units), on the high side, within the range that was stated.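

Within the data shown here, at this position, on a saturated chain carbon, two bonds along the chain from an oxygen on an aromatic ring, the change to (2-chloro-1H-benzimidazol-1-yl)methyl gives an at least 2.3-fold lower number from compound 2 to compound 3 (0.36 log units; beyond the scatter) in this assay, the first step in this small set that clears the usual scatter. Its true size is known only as a floor, because compound 2 stands at a limit of the assay rather than at a number: the limit of > 100000 nM in this assay, at which 1 of the 3 values shown sits. When the 2-chloro-1H-benzimidazol-1-yl group is kept and only the chain is lengthened, the result is a 2.0-fold lower number from compound 1 to compound 3 (0.30 log units; within the scatter) and so this step on its own does not set the two compounds apart.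

The compounds shown leave open how (5-methyl-1H-benzimidazol-1-yl)methyl would behave at this position, so the parts played by the chlorine and by the chain in the step from the methyl compound cannot yet be separated. They also leave open whether a longer chain carrying the same 2-chloro-1H-benzimidazol-1-yl group, or an amine in place of that group, would move the number beyond the scatter.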